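This account rests on a few compounds, and the source may have more. Where it says the series, first, only, none or still open, it means among the compounds named here.

Of the compounds shown here, three built on one shared core have so far been tested in a functional assay on HCT-116 cells (Homo sapiens) for inhibition, read by MTT assay, with a stated time of 72 h; a higher number here means a weaker inhibitor, a lower number a stronger inhibitor. Compound 1 `Cc1cccc(NC(=O)c2ccc(/N=N\c3c[nH]c4ccccc34)cc2)c1C` gives 272000 nM. Compound 2 `O=C(Nc1cccc(Cl)c1)c1ccc(/N=N\c2c[nH]c3ccccc23)cc1` gives 80000 nM. Compound 3 `COc1ccccc1NC(=O)c1ccc(/N=N\c2c[nH]c3ccccc23)cc1` gives 122000 nM, which places it second highest of the three numbers, with compound 1 the only one clearly above it. The three differ only in the substituted phenyl group on the amide-type nitrogen. a 2.2-fold lower number from compound 1 to compound 3 (0.35 log units; beyond the scatter), while a 1.5-fold higher number from compound 2 to compound 3 (0.18 log units; within the scatter), so exchanging one substituted phenyl for another has moved the number modestly at most.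

Compound 4 `O=C(Nc1ccccc1F)c1ccc(/N=N\c2c[nH]c3ccccc23)cc1` is the next member of the set and differs from compound 3 by fluoro in place of methoxy on an aromatic carbon. Going by the values given here, the steps that bear on this change are a 3.4-fold lower number from compound 1 to compound 2 (0.53 log units; beyond the scatter) and a 2.2-fold lower number from compound 1 to compound 3 (0.35 log units; beyond the scatter), both modest, and the step between compound 2 and compound 3 sits within the scatter. A shift of similar modest size, or none beyond the scatter, is therefore expected, with no clear direction. Compound 4 is estimated at 100000 nM, within a range of 40000 nM to 250000 nM. The expected step is then a 1.2-fold lower number from compound 3 to compound 4 (0.09 log units; within the scatter).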

Compound 4, half-maximal inhibitory concentration: 559000 nM
Compound 4: the middle estimate sits 5.6-fold (0.75 log units) below what was measured, and the stated range ends below it.
By their numbers in this assay, from the lowest: compounds 2 and 3 (each within the scatter of the next); then compound 1; then compound 4.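

In this assay, fluoro in place of methoxy on this aromatic carbon, ortho to a large group, gives a 4.6-fold higher number from compound 3 to compound 4 (0.66 log units; beyond the scatter), a larger shift than any step among the first three compounds, so the group at this one place can matter more than those earlier swaps suggested. Going by these compounds alone, compound 4 is also the weakest of the four, with a 7.0-fold higher number from compound 2 to compound 4 (0.84 log units; beyond the scatter) and a 2.1-fold higher number from compound 1 to compound 4 (0.31 log units; beyond the scatter), which shows that a single fluoro on the phenyl group does not keep the number within the span of the earlier compounds. No measurement available here accounts for this shift.

On these data alone, only methoxy and fluoro can be compared directly at this place, so it remains open whether the number depends on the group's size or on something else. As far as these compounds go, how the unsubstituted phenyl, an amine or a hydroxyl group would behave there also remains open.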